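Imide-to-fluoro swap on the benzoate ester series

A few compounds are considered here, and "the series" means these few. Any claim that something is new, unique, unknown or untested is made for them only; others in the source may bear on it.

Measured so far in a functional assay with Neuronal acetylcholine receptor; alpha3/beta4 (Homo sapiens) as the target; on this read-out lower numbers stand for stronger inhibition and higher numbers for weaker inhibition:
- compound 1 `CC1(C)CC(=O)N(c2ccccc2C(=O)OCC2CCCN(CCCc3ccccc3)C2)C1=O`: 7500 nM
- compound 2 `CCCCCCCCC1CC(=O)N(c2ccccc2C(=O)OCC2CCCN(CCCc3ccccc3)C2)C1=O`: 1300 nM
- compound 3 `O=C(OCC1CCCN(CCCc2ccccc2)C1)c1ccccc1N1C(=O)CC(C2CCCC2)C1=O`: 1200 nM

Compound 3 holds the lowest of the three numbers; its value and that of compound 2 are within the scatter of each other, while compound 1 sits clearly higher, as the step of a 6.3-fold lower number from compound 1 to compound 3 (0.80 log units; beyond the scatter) shows. The step of a 1.1-fold lower number from compound 2 to compound 3 (0.03 log units; within the scatter) adds nothing beyond the scatter.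

Compound 4 `O=C(OCC1CCCN(CCCc2ccccc2)C1)c1ccccc1F` differs from compound 3 by one fluorine atom in place of a group of 12 heavy atoms (9 carbon, 1 nitrogen, 2 oxygen; one five-membered non-aromatic ring of carbon only, one five-membered non-aromatic ring with 1 hetero atom), on an aromatic carbon. For the measured compounds named here, no measured step removes the whole imide ring; the only steps bearing on it, a 6.3-fold lower number from compound 1 to compound 3 (0.80 log units; beyond the scatter) and a 1.1-fold lower number from compound 2 to compound 3 (0.03 log units; within the scatter), change substituents on that ring and show that its substitution pattern can shift the read-out by a modest amount. With the ring gone altogether, a step of at least that size toward a higher number is expected, with wide uncertainty because no reference a 6.3-fold lower number from compound 1 to compound 3 (0.80 log units; beyond the scatter) covers this kind of change directly.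

Compound 4 is estimated at 10000 nM (range 2000 nM to 50000 nM), an expected step of an 8.3-fold higher number from compound 3 to compound 4 (0.92 log units; beyond the scatter) relative to compound 3.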

Compound 4, half-maximal inhibitory concentration: 5200 nM
Compound 4: middle estimate off by 1.9-fold (0.28 log units), on the high side; measured number inside the range.
By their numbers in this assay, from the lowest: compounds 3 and 2 (each within the scatter of the next); then compounds 4 and 1 (each within the scatter of the next).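

In this assay, for the compounds shown here, fluoro in place of the cyclopentyl-bearing imide on this aromatic carbon gives a readable loss (a 4.3-fold higher number from compound 3 to compound 4 (0.64 log units; beyond the scatter)), the first measured step that removes the whole group. The same replacement of 3,3-dimethyl-2,5-dioxopyrrolidin-1-yl gives no separation (a 1.4-fold lower number from compound 1 to compound 4 (0.16 log units; within the scatter)), so among these compounds the imide ring alone confers no advantage over a single fluorine, and the gain seen with compound 3 depends on what the ring carries. No evidence here bears on the reason for either step.

Still open, from the compounds shown here alone, is whether a hydrogen, an amine or a carboxylic acid on this aromatic carbon would stay level with fluoro or reach the number of compound 3. Also open, going by these compounds, is whether a phenyl group on the imide ring would go beyond cyclopentyl and octyl, which remain level.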